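A few compounds are considered here, and "the series" means these few. Any claim that something is new, unique, unknown or untested is made for them only; others in the source may bear on it.

In a functional assay on U-87MG ATCC cells (Homo sapiens) for cytotoxicity, read by MTT assay, with a stated time of 48 h (a lower number here means a stronger inhibitor, a higher number a weaker inhibitor), compound 3 `C/C(=N\NC(=S)Nc1ccccc1)c1ccccn1`, with hydrogen at the site in question, gives 1.4 nM. Compound 1 `C/C(=N\NC(=S)Nc1ccc(Cl)cc1)c1ccccn1` gives 1.7 nM, and with a 1.2-fold lower number from compound 1 to compound 3 (0.08 log units; within the scatter) these two form the low end of the three numbers. Compound 2 `C/C(=N\NC(=S)Nc1ccc(I)cc1)c1ccccn1` stands well apart at 59 nM, and the return to hydrogen is a 42-fold lower number from compound 2 to compound 3 (1.62 log units; beyond the scatter).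

Compound 4 `C/C(=N\NC(=S)Nc1ccc(F)cc1)c1ccccn1` has not been measured. Its change from compound 3 is fluoro in place of hydrogen on an aromatic carbon, para to a large group. Two measured steps at the same place bear on it. The chloro exchange is a 1.2-fold lower number from compound 1 to compound 3 (0.08 log units; within the scatter), while the iodo exchange is large, at a 35-fold higher number from compound 1 to compound 2 (1.54 log units; beyond the scatter). Halogen at this place therefore does not give one outcome, and compound 2 goes against compound 1. Fluoro is expected to follow chloro, so no step beyond the scatter is expected in this assay, with the greater risk towards a higher number. The expected step is a 1.1-fold higher number from compound 3 to compound 4 (0.06 log units; within the scatter). The estimated value for compound 4 is 1.6 nM, with an estimated range of 0.5 nM to 8 nM.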

Compound 4, half-maximal inhibitory concentration: 10 nM
Compound 4: middle estimate off by 6.3-fold (0.80 log units), on the low side, and the stated range ends below it.
By their numbers in this assay, from the lowest: compounds 3 and 1 (each within the scatter of the next); then compound 4; then compound 2.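

In this assay, fluoro at this place does shift the number, with a 7.1-fold higher number from compound 3 to compound 4 (0.85 log units; beyond the scatter) and so a step beyond the scatter, whereas chloro stays within the scatter of hydrogen. Chloro and fluoro also part from each other, with a 5.9-fold higher number from compound 1 to compound 4 (0.77 log units; beyond the scatter) as the step between them, while a 5.9-fold lower number from compound 2 to compound 4 (0.77 log units; beyond the scatter) leaves fluoro well short of iodo, so the halogens shown give no steady trend from fluoro through chloro to iodo, and compound 1 is the one that goes against it. No measurement on hand accounts for this order of the halogens.

As far as these compounds go, whether the low number of compound 1 is a lone case among the halogens stays open, and bromo at this place would test that. Whether the higher numbers are confined to halogens also stays open, as the compounds shown include no methoxy, amine or carboxylic acid here.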